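Aryl variation on the ring nitrogen of the thiazolidinone series

The source may report more compounds than this note shows. Statements on the series, on what has been measured and on what is new or still open speak of the compounds shown alone.

Measured so far:
compound 1 `COc1ccc(F)cc1N1C(=O)CSC1c1cccc(C(=O)NCCCCc2ccccc2)c1` gives 32%
compound 2 `COc1cc(F)ccc1N1C(=O)CSC1c1cccc(C(=O)NCCCCc2ccccc2)c1` gives 34%
compound 3 `O=C(NCCCCc1ccccc1)c1cccc(C2SCC(=O)N2c2ccccc2F)c1` gives 38%

All three values come from a functional assay on U2OS cells (Homo sapiens) for inhibition, read by CCK-8 assay, with a stated time of 72 h, tested at 1 uM; a higher number here means more inhibition at the concentration tested (going by the name of the read-out), a lower number less inhibition. Compound 3 carries the highest of the three numbers, but every gap to it lies within the scatter: the nearest is compound 2, with a number 4 percentage points higher from compound 2 to compound 3 (within the scatter), and the furthest is compound 1, with a number 6 percentage points higher from compound 1 to compound 3 (within the scatter). The remaining pair behaves the same way, a number 2 percentage points higher from compound 1 to compound 2 (within the scatter). So far, swapping the aryl group on the amide-type nitrogen in the ring has not moved the read-out by more than the scatter.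

Compound 4 `CC(F)(F)c1cccc(N2C(=O)CSC2c2cccc(C(=O)NCCCCc3ccccc3)c2)c1` is not yet measured in this assay. Relative to compound 3 the change is a group of 10 heavy atoms (8 carbon, 2 fluorine; one six-membered aromatic ring of carbon only) in place of a group of 7 heavy atoms (6 carbon, 1 fluorine; one six-membered aromatic ring of carbon only), on an amide-type nitrogen in a ring. Within the data shown here, no measured step puts a two-fluorine group on this aryl ring, so the only steps that bear on it are the three aryl swaps noted above, all within the scatter. The expectation is therefore no step beyond the scatter, a number 2 percentage points lower from compound 3 to compound 4 (within the scatter). Compound 4 is estimated at 36%, with a range from 22% to 50%.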

Compound 4, a percentage reported as inhibition, at one concentration (the size of the read-out at that concentration, not a potency) in the U2OS assay: 24%
Estimate against measurement, compound 4: 12 percentage points above; the measured number falls inside the stated range.
By their numbers in the U2OS assay, from the lowest: compounds 4, 1, 2 and 3 (each within the scatter of the next, the first and the last beyond it).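

Among these compounds, in the U2OS assay, the two-fluorine aryl group on the amide-type nitrogen in a ring gives the first step beyond the scatter at this position, a number 14 percentage points lower from compound 3 to compound 4 (beyond the scatter), whereas the other two steps remain within it, a number 10 percentage points lower from compound 2 to compound 4 (within the scatter) and a number 8 percentage points lower from compound 1 to compound 4 (within the scatter). The position is therefore not wholly indifferent to the aryl group, although compound 4 separates only from compound 3 and the size of that step is modest. In a physicochemical assay for solubility, read by turbidimetry, measured as kinetic solubility, at pH 7.4 (on this read-out lower numbers stand for lower solubility and higher numbers for higher solubility), compound 3 gives 10000 nM and compound 4 gives 2000 nM. The same change also lowers the reading in the physicochemical assay, so less compound in solution could contribute to the lower inhibition, though a single pair cannot settle this: the measured solubility of compound 3, 10000 nM, and of compound 4, 2000 nM, a 5.0-fold lower number (0.70 log units; beyond the scatter)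

The compounds shown do not separate the contribution of the two fluorines from that of the larger group as a whole, and they leave open whether the lower inhibition and lower solubility are linked. An aryl group carrying an amine or a carboxylic acid in place of the two-fluorine group would test whether inhibition and solubility move together at this position.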